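The source may hold more compounds than are shown below. What is called first, only, known or untested is meant among the compounds shown, and "the series" means these compounds.

Compound 1 `COc1cc(C(=O)N/N=C/c2cccc(F)c2)cc(OC)c1OC` is the reference point of this set. In a functional assay on PC-3 cells (Homo sapiens) for antiproliferative activity, read by MTT assay, tested at 1 uM (a higher number here means a stronger effect of the compound at the concentration tested, a lower number a weaker effect), compound 1 gives 53.5%, the highest of the three numbers recorded here. Going by the values given here, its nearest neighbour is compound 3 `COc1cc(C(=O)N/N=C/c2cccc(C(F)(F)F)c2)cc(OC)c1OC`, which in this assay gives 51%; the step of a number 2.5 percentage points lower from compound 1 to compound 3 (within the scatter) is the only one-place change among the measured compounds. Compound 2 `COc1cc(C2=NN(C(C)=O)C(c3cccc(OC)c3OC)O2)cc(OC)c1OC`, which carries a different core, gives 35% in this assay, a number that stands well apart from that of compound 1.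

The compound now in question is compound 4 `COc1cc(C(=O)N/N=C/c2ccc(Cl)c(Cl)c2)cc(OC)c1OC`. It differs from compound 1 in one place: 3,4-dichlorophenyl in place of 3-fluorophenyl on a carbon with a double bond to nitrogen. Among the compounds with values here, the one measured step that bears on this change is that from compound 1 to compound 3, in which a different substituent on the same aromatic ring left the read-out within the scatter. Within the data shown here, no measured step covers a second halogen on that ring, so the expectation rests on compound 1 alone and on the small size of a number 2.5 percentage points lower from compound 1 to compound 3 (within the scatter). Compound 4 is therefore expected to show no step beyond the scatter, with an estimated change of a number 1.5 percentage points lower from compound 1 to compound 4 (within the scatter). Compound 4 is estimated at 52%, in a range from 38% to 66%.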

Compound 4, a percentage reported as inhibition, at one concentration (the size of the read-out at that concentration, not a potency): 13.5%
Estimate against measurement, compound 4: 38.5 percentage points above; measured number outside the range, below it.
By their numbers in this assay, from the lowest: compound 4; then compound 2; then compounds 3 and 1 (each within the scatter of the next).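

Compound 4 shows that the read-out in this assay is not indifferent to the aryl group on the carbon with a double bond to nitrogen: the change to 3,4-dichlorophenyl gives a number 40 percentage points lower from compound 1 to compound 4 (beyond the scatter) on the shared core. The earlier step, a number 2.5 percentage points lower from compound 1 to compound 3 (within the scatter), showed only that trifluoromethyl in place of fluoro on that ring leaves the read-out within the scatter, so the tolerance seen there does not extend to every halogen-bearing phenyl group. No measurement on hand offers an explanation for this large loss, and the drop remains an observation without a stated cause.

The change replaces fluoro with two chlorines at once, so the compounds shown cannot tell whether the loss comes from chlorine itself, from the second substituent or from the two together, and a phenyl ring with a single chlorine would be needed to separate these. Going by these compounds, it also remains open how a methoxy, a hydroxyl or an amine on that ring would behave, and whether the step would hold at concentrations other than the single one tested.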